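The source may hold more compounds than are shown below. What is called first, only, known or untested is meant among the compounds shown, and "the series" means these compounds.

Measured in a functional assay on HCT-116 cells (Homo sapiens) for cytotoxicity, read by sulforhodamine B assay, with a stated time of 24 h; on this read-out higher numbers stand for weaker inhibition and lower numbers for stronger inhibition:
compound 1 `CC(C)CCC(=O)Nc1ccn([C@H]2CC[C@H](O[C@H]3O[C@H](C)[C@@H](N(C)C)[C@H](O)[C@H]3O)[C@@H](C)O2)c(=O)n1` gives 390 nM;
compound 2 `C[C@H]1O[C@@H](n2ccc(NC(=O)CC(C)(C)O)nc2=O)CC[C@@H]1O` gives > 20000 nM;
compound 3 `CCC(C)/C=C/C(=O)Nc1ccn([C@H]2CC[C@H](O[C@H]3O[C@H](C)[C@@H](N(C)C)[C@H](O)[C@H]3O)[C@@H](C)O2)c(=O)n1` gives 890 nM.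

Compound 2 stands apart from the other two: its result is a limit of the assay, not a number, and it sits at the limit of > 20000 nM in this assay, at which 1 of the 3 values shown sits, the weak end of what was recorded. Compound 4 `CC(C)/C=C/C(=O)Nc1ccn([C@H]2CC[C@H](O)[C@@H](C)O2)c(=O)n1` shares the core of compound 2 and differs from it in one place, (3-methylbut-1-en-1-yl in place of 2-hydroxy-2-methylpropyl on a carbonyl carbon). Within the data shown here, the only measured step within this set is a 2.3-fold higher number from compound 1 to compound 3 (0.36 log units; beyond the scatter), a change on the same carbonyl carbon but of a different kind, on compounds that carry an additional sugar unit that compounds 2 and 4 lack. That step bears on the present one only loosely, and it points, if anywhere, toward a weaker result rather than a stronger one. The expected step in this assay is therefore a number no higher from compound 2 to compound 4 (the limit leaves the size open), which is to say no gain beyond the scatter. Compound 4 is estimated at 20000 nM, within a range of 5000 nM to 60000 nM, most likely again reported as a limit.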

Compound 4, half-maximal inhibitory concentration: > 20000 nM
Compound 4 was reported as a limit (the forecaster's own chance of this, stated with the estimate: 70%); the middle value lies on the limit itself.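

Compound 2 and compound 4 each gave a limit of the assay rather than a number, so no step between them can be read: the limit of > 20000 nM in this assay, at which 2 of the 4 values shown sit.

The compounds shown leave open whether 3-methylbut-1-en-1-yl in place of 2-hydroxy-2-methylpropyl on the carbonyl carbon changes the result at all.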